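The compounds below may be only part of what the source reports. "The series", "measured", "known", "first", "only" and "open" are said of these compounds alone.

Among the measured compounds shown here, in a functional assay on HL-60 cells (Homo sapiens) for cytotoxicity, read by MTT assay (a higher number here means a weaker inhibitor, a lower number a stronger inhibitor), only two numbers exist so far. For compound 1 `COc1ccc(S(=O)(=O)NC(C2=CC(=O)c3c(O)ccc(O)c3C2=O)C(C)C)cc1` the entry reads "not determined" (no result reported) and gives no number. Compound 2 `COc1ccc(S(=O)(=O)NC(C2=CC(=O)c3c(O)ccc(O)c3C2=O)C(C)C)c(OC)c1` gives 400 nM and compound 3 `CC(C)C(NS(=O)(=O)c1ccccc1Br)C1=CC(=O)c2c(O)ccc(O)c2C1=O` gives 340 nM so compound 3 stands level with compound 2 within the scatter.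

Next comes compound 4 `CCOC(=O)c1ccc(S(=O)(=O)NC(C2=CC(=O)c3c(O)ccc(O)c3C2=O)C(C)C)cc1` with 4-(ethoxycarbonyl)phenyl in place of 2-bromophenyl on a sulfonyl sulfur, counted as 4-(ethoxycarbonyl)phenyl in place of 2-bromophenyl on a sulfonyl sulfur at that place. For the measured compounds named here, the only measured step on this sulfur is a 1.2-fold lower number from compound 2 to compound 3 (0.07 log units; within the scatter) and it stays within the scatter. Going by the values given here, that step is a single one, and no measured compound carries the ethoxycarbonyl group, so the support is thin. No step beyond the scatter is expected in this assay and no direction can be given with confidence. The expected change is a 1.1-fold higher number from compound 3 to compound 4 (0.05 log units; within the scatter) and it would lie within the scatter. Compound 4 is estimated at 380 nM with an expected range from 160 nM to 900 nM for now.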

Compound 4, half-maximal inhibitory concentration: 150 nM
For compound 4 the middle estimate is 2.5-fold (0.40 log units) above the measured one; measured number outside the range, below it.
By their numbers in this assay, from the lowest: compound 4; then compounds 3 and 2 (each within the scatter of the next).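

In this assay the group on the sulfonyl sulfur now makes a difference beyond the scatter: 4-(ethoxycarbonyl)phenyl in place of 2-bromophenyl gives a 2.3-fold lower number from compound 3 to compound 4 (0.36 log units; beyond the scatter), and in place of 2,4-dimethoxyphenyl it gives a 2.7-fold lower number from compound 2 to compound 4 (0.43 log units; beyond the scatter). Among the compounds shown here, the earlier exchange of 2,4-dimethoxyphenyl for 2-bromophenyl stayed within the scatter, so this is the first sign that the aryl group at this place affects the read-out, although both steps are modest and both rest on compound 4 alone. Nothing measured here explains the lower number.

It remains open whether the ester itself carries the step, as the compounds shown include no carboxylic acid, primary amide or methyl ester at this place. Going by these compounds, how an unsubstituted phenyl group would compare with these aryl groups also remains open.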